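A few compounds are considered here, and "the series" means these few. Any claim that something is new, unique, unknown or untested is made for them only; others in the source may bear on it.

Compound 1 `COc1ccc(/C=C\c2cc(OC)c(OC)c(OC)c2)cc1OCc1ccc(CN2C[C@H](O)C[C@@H]2C(=O)O)cc1`: > 50000 nM
Compound 2 `COc1ccc(/C=C\c2cc(OC)c(OC)c(OC)c2)cc1OCc1ccc(CN2CCCC[C@H]2C(=O)O)cc1`: > 50000 nM
Compound 3 `COc1ccc(/C=C\c2cc(OC)c(OC)c(OC)c2)cc1OCc1ccc(CN2CCCCC2C(=O)O)cc1`: > 50000 nM

All three entries come from an ADME assay on NCM460 cells (Homo sapiens) for cytotoxicity, read by CCK-8 assay, with a stated time of 48 h (on this read-out higher numbers stand for weaker inhibition and lower numbers for stronger inhibition), and each is a limit of the assay, not a number. Going by the values given here, the series so far sits at the limit of > 50000 nM in this assay, at which 3 of the 3 values shown sit. In this assay compound 3 gives a limit, > 50000 nM, and no number.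

The next structure is compound 4 `COc1ccc(/C=C\c2cc(OC)c(OC)c(OC)c2)cc1OCc1ccc(CN2CC[C@H](C(=O)O)C2)cc1`. The change is 3-carboxypyrrolidin-1-yl in place of 2-carboxypiperidin-1-yl on a saturated chain carbon bound to an aromatic carbon. In words, 3-carboxypyrrolidin-1-yl stands in place of 2-carboxypiperidin-1-yl on a saturated chain carbon bound to an aromatic carbon.

The closest measured precedents exchange groups at this same place: a step that the two limits leave unreadable from compound 1 to compound 3, and likewise a step that the two limits leave unreadable from compound 1 to compound 2. The remaining measured step is a step that the two limits leave unreadable from compound 2 to compound 3, and it reflects (the fact that one of compounds 2 and 3 is drawn with a defined configuration and the other without, at the place where they differ). None of these steps has a readable size, so none sets a direction for the new change. The expectation therefore rests on compound 3 and its limit of > 50000 nM, together with the shared position of the series at that limit.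

The expected change is a number no higher from compound 3 to compound 4 (the limit leaves the size open), with no direction expected beyond the scatter in this assay. A further limit is the most likely report. For compound 4 the estimate is 50000 nM, with an expected range of 25000 nM to 100000 nM.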

Compound 4, half-maximal inhibitory concentration: > 50000 nM
Compound 4: only a limit was reported; the forecaster's own chance of this, stated with the estimate: 85%; the middle value lies on the limit itself.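

In this assay compound 4 gives > 50000 nM, a limit of the assay and not a number. No new step can be read: the steps from compound 1, compound 2 and compound 3 to compound 4 all have limits at both ends. The compounds shown leave open whether the group exchanges at this place, or the drawn configuration, change the read-out at all.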